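Cytotoxicity notes: aryl swap on the shared core

A few compounds are considered here, and "the series" means these few. Any claim that something is new, unique, unknown or untested is made for them only; others in the source may bear on it.

Measured so far, in an ADME assay on BaF3 cells (Mus musculus) for cytotoxicity; on this read-out lower numbers stand for an effect already at smaller amounts and higher numbers for an effect only at larger amounts of compound:
compound 1 `Nc1cccc(-c2cc(Nc3ccc(OC(F)(F)F)cc3)ncn2)c1` gives > 10000 nM
compound 2 `CNC(=O)c1cccc(-c2cc(Nc3ccc(OC(F)(F)F)cc3)ncn2)c1` gives > 10000 nM

The value of compound 1 is a limit of the assay, not a number. The value of compound 2 is likewise a limit. Among the measured compounds shown here, compound 1 therefore stands only at a limit, and the one other value shown is also a limit, so no order between the two can be stated. For the measured compounds named here, the single measured step, a step that the two limits leave unreadable from compound 1 to compound 2, has no readable size because the limit of > 10000 nM in this assay, at which 2 of the 2 values shown sit, holds both of its ends.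

Compound 3 `FC(F)(F)Oc1ccc(Nc2cc(-c3ccc4[nH]ccc4c3)ncn2)cc1` is not yet measured in this assay. It differs from compound 1 by 1H-indol-5-yl in place of 3-aminophenyl on an aromatic carbon. Going by the values given here, no measured step covers this change; the only step known touches a different substituent and is itself unreadable. Both measured compounds sit at the limit, and nothing shown points to compound 3 leaving it. Compound 3 is therefore expected to give about 15000 nM, with a range from 5000 nM to 50000 nM. The step that the limit leaves unreadable from compound 1 to compound 3 is accordingly expected to be none beyond the scatter.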

Compound 3, half-maximal effective concentration: > 10000 nM
Compound 3 gave a limit, no number; the forecaster's own chance of this, stated with the estimate: 75%; the middle value lies beyond the limit too.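

In this assay compound 3 gives > 10000 nM, a limit and not a number. The step between compound 1 and compound 3 therefore cannot be read, and the values shown share one ceiling: the limit of > 10000 nM in this assay, at which 3 of the 3 values shown sit.

The compounds shown leave open whether any change on the shared core yields a measurable number in this assay.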